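Aryl variation on the triazole nitrogen: hepatic cell series

The compounds below may be only part of what the source reports. "The series", "measured", "known", "first", "only" and "open" are said of these compounds alone.

Measured so far in an ADME assay on L02 cells (Homo sapiens) for antiproliferative activity, read by MTT assay, with a stated time of 48 h; on this read-out higher numbers stand for weaker inhibition and lower numbers for stronger inhibition:
compound 1 `Cc1cccc(-n2nncc2CN2C(=O)C3(C(C#N)=C(N)Oc4c(N)cc5nc6ccccc6nc5c43)c3ccccc32)c1` gives > 50000 nM, a limit of the assay.
compound 2 `N#CC1=C(N)Oc2c(N)cc3nc4ccccc4nc3c2C12C(=O)N(Cc1cnnn1-c1ccccc1Br)c1ccccc12` gives 29200 nM.
compound 3 `N#CC1=C(N)Oc2c(N)cc3nc4ccccc4nc3c2C12C(=O)N(Cc1cnnn1-c1cc(Cl)ccc1Cl)c1ccccc12` gives > 50000 nM, a limit of the assay.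

Compound 3 stands at the top of what this assay reports: its value is a limit, not a number, and compound 1 sits at the same limit (the limit of > 50000 nM in this assay, at which 2 of the 3 values shown sit). The next compound, compound 4 `Cc1cc(C)c(-n2nncc2CN2C(=O)C3(C(C#N)=C(N)Oc4c(N)cc5nc6ccccc6nc5c43)c3ccccc32)c(C)c1`, carries the change (2,4,6-trimethylphenyl in place of 2,5-dichlorophenyl on an aromatic nitrogen).

Steps that bear on it are the exchanges of the aryl group on the same aromatic nitrogen. The step of an at least 1.7-fold lower number from compound 1 to compound 2 (0.23 log units; that floor lies within the scatter) and the step of an at least 1.7-fold higher number from compound 2 to compound 3 (0.23 log units; that floor lies within the scatter) are both floors within the scatter, and the step that the two limits leave unreadable from compound 1 to compound 3 cannot be sized at all, since both ends are limits. No exchange of this aryl group has so far moved the read-out beyond the scatter, so for compound 4 no step beyond the scatter is expected in either direction; the step of an at least 1.1-fold lower number from compound 3 to compound 4 (0.04 log units; that floor lies within the scatter) is the estimate, with a real chance that only a limit is reported again. Compound 4 is therefore expected at 45000 nM, within 20000 nM to 100000 nM.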

Compound 4, half-maximal inhibitory concentration: > 50000 nM
Compound 4: a limit, no number; the forecaster's own chance of this, stated with the estimate: 60%; middle value at least 1.1-fold (0.04 log units) away from the limit.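

In this assay compound 4 gives > 50000 nM, a limit of the assay and not a number. Among the compounds shown here, the one readable new step is an at least 1.7-fold higher number from compound 2 to compound 4 (0.23 log units; that floor lies within the scatter), so the 2-bromophenyl group is still not set apart from the other aryl groups by more than the scatter, while the steps among the compounds at the limit cannot be read. With 2,4,6-trimethylphenyl on the aromatic nitrogen, a third aryl pattern, carrying only methyl groups and more of them than 3-methylphenyl, ends at the same limit as 3-methylphenyl and 2,5-dichlorophenyl: the limit of > 50000 nM in this assay, at which 3 of the 4 values shown sit.

From the compounds shown here alone, how far apart compound 1, compound 3 and compound 4 truly lie remains open. Also open, going by these compounds, is whether a phenyl group bearing an amine or a carboxylic acid on this nitrogen would give a number clearly below the limit.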